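Amide Carbonyl Substituent Variation in the Series

The source may hold more compounds than are shown below. What is called first, only, known or untested is meant among the compounds shown, and "the series" means these compounds.

Compound 2 `CN1CCC(c2c[nH]c3ccc(NC(=O)C4CC4)nc23)CC1` stands lowest of the three numbers measured in an assay for binding affinity to 5-hydroxytryptamine receptor 1F (Homo sapiens), read by radioligand binding; a lower number here means a stronger inhibitor, a higher number a weaker inhibitor: compound 2 gives 9.8 nM. Compound 1 `CCCCCCCC(=O)Nc1ccc2[nH]cc(C3CCN(C)CC3)c2n1`, carrying heptyl on the carbonyl carbon, gives 20 nM in this assay, and compound 3 `CN1CCC(c2c[nH]c3ccc(NC(=O)C4CCCCC4)nc23)CC1`, carrying cyclohexyl there, gives 20 nM. The steps of a 2.0-fold lower number from compound 1 to compound 2 (0.31 log units; beyond the scatter) and a 2.0-fold higher number from compound 2 to compound 3 (0.31 log units; beyond the scatter) both lie beyond the scatter, so compound 2 is the most potent of the three, whereas no change at the digits printed from compound 1 to compound 3 (within the scatter).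

Compound 4 `CCCC(=O)Nc1ccc2[nH]cc(C3CCN(C)CC3)c2n1` differs from compound 2 by propyl in place of cyclopropyl on a carbonyl carbon. Within the data shown here, both measured steps that exchange cyclopropyl for another group read a modest rise, and the open heptyl chain of compound 1 and the cyclohexyl ring of compound 3 give numbers indistinguishable from each other, so the three-membered ring is the one feature that sets compound 2 apart. Among the measured compounds shown here, no measured step compares two open chains of differing length. The expectation is therefore a modest rise in this assay for compound 4, estimated as a 1.6-fold higher number from compound 2 to compound 4 (0.21 log units; within the scatter). Compound 4 is estimated at 16 nM, within 7 nM to 35 nM.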

Compound 4, inhibition constant: 6.9 nM
Estimate against measurement, compound 4: 2.3-fold (0.37 log units) above; measured number below the stated range.
By their numbers in this assay, from the lowest: compounds 4 and 2 (each within the scatter of the next); then compounds 1 and 3 (each within the scatter of the next).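

In this assay, the step from the ring to the open chain stays small (a 1.4-fold lower number from compound 2 to compound 4 (0.15 log units; within the scatter)), so the cyclopropyl ring is not the feature that sets compound 2 apart from compound 1 and compound 3. Open chains on the carbonyl carbon can now be compared directly, and the shorter chain gives the lower number (a 2.9-fold lower number from compound 1 to compound 4 (0.46 log units; beyond the scatter)); the propyl amide also separates from the cyclohexyl amide (a 2.9-fold lower number from compound 3 to compound 4 (0.46 log units; beyond the scatter)). Across these four compounds, the groups of 3 carbon atoms, propyl and cyclopropyl, both stand beyond the scatter from heptyl and cyclohexyl, and no compound goes against this split.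

Still open, on these data alone, is how a methyl or tert-butyl group on the carbonyl carbon, or a chain carrying an amine, would read in this assay. Nothing available here gives a cause for the split.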